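Fluoro for bromo on the nitro compound

The source may report more compounds than this note shows. Statements on the series, on what has been measured and on what is new or still open speak of the compounds shown alone.

In a functional assay on K562 cells (Homo sapiens) for cytotoxicity, read by trypan blue exclusion, with a stated time of 96 h (a higher number here means a weaker inhibitor, a lower number a stronger inhibitor), compound 1 (`COc1cc(OC)c(/C=C/S(=O)(=O)Cc2ccc(F)c(N)c2)c(OC)c1`) gives 2500 nM and compound 2 (`COc1cc(OC)c(/C=C/S(=O)(=O)Cc2ccc(Br)c([N+](=O)[O-])c2)c(OC)c1`) gives 25000 nM. Compound 2 therefore holds the higher of the two numbers, making it the weaker inhibitor of the pair by a gap beyond the scatter.

Compound 3 (`COc1cc(OC)c(/C=C/S(=O)(=O)Cc2ccc(F)c([N+](=O)[O-])c2)c(OC)c1`) follows from compound 2 by fluoro in place of bromo on an aromatic carbon, with the new fluoro ortho to a nitro group. Within the data shown here, no measured pair isolates this exchange. Compound 1 also carries fluoro and gives 2500 nM, but it has an amino group in place of the nitro group, so it is only a loose guide. A clear step towards a lower number in this assay is expected, though its size is uncertain. The expected 8.3-fold lower number from compound 2 to compound 3 (0.92 log units; beyond the scatter) rests on that single comparison. For compound 3, the estimated value is 3000 nM, with an expected range of 250 nM to 25000 nM.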

Compound 3, half-maximal inhibitory concentration: 25000 nM
Compound 3: the middle estimate sits 8.3-fold (0.92 log units) below what was measured; the measured number falls inside the stated range.
By their numbers in this assay, from the lowest: compound 1; then compounds 2 and 3 (each within the scatter of the next).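

With the nitro group held, fluoro in place of bromo on this aromatic carbon gives no change at the digits printed from compound 2 to compound 3 (within the scatter) in this assay and so does not separate the pair. With fluoro held, nitro in place of amino gives a 10-fold higher number from compound 1 to compound 3 (1.00 log units; beyond the scatter) as the only single-place step here beyond the scatter, so among the compounds shown, the nitro-to-amino exchange, not the halogen exchange, goes with a difference in this read-out. Nothing available explains either step.

From the compounds shown here alone, the halogen exchange is seen only alongside the nitro group, so whether bromo and fluoro also match alongside an amino group remains open. Also open, going by these compounds, is how chloro or methoxy would read on the halogen carbon, and how an acetamide or a carboxylic acid would read in place of the amino group.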